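From tert-butyl to methyl on the aromatic ring

This account rests on a few compounds, and the source may have more. Where it says the series, first, only, none or still open, it means among the compounds named here.

In a functional assay on MGC-803 cells (Homo sapiens) for antiproliferative activity, read by MTT assay, with a stated time of 48 h (on this read-out higher numbers stand for weaker inhibition and lower numbers for stronger inhibition), compound 1 `CCc1ccccc1NC(=O)Nc1cccc(CNc2nccnc2Cl)c1` gives 9370 nM, compound 2 `Cc1ccc(NC(=O)Nc2cccc(CNc3nccnc3Cl)c2)cc1C` gives 9870 nM and compound 3 `CC(C)(C)c1ccc(NC(=O)Nc2cccc(CNc3nccnc3Cl)c2)cc1` gives 4820 nM. Compound 3 stands within the scatter of compound 1 and just beyond it, on the lower side, of compound 2. Compound 4 `Cc1ccc(NC(=O)Nc2cccc(CNc3nccnc3Cl)c2)cc1` has methyl in place of tert-butyl on an aromatic carbon, para to a large group (methyl in place of tert-butyl on an aromatic carbon). Going by the values given here, the only measured step, a 1.1-fold higher number from compound 1 to compound 2 (0.02 log units; within the scatter), does not test this change directly. Compound 2 also carries methyl on that ring, at 9870 nM, so a small rise in this assay is expected. The expected step is a 1.7-fold higher number from compound 3 to compound 4 (0.22 log units; within the scatter). For compound 4 the estimate is 8000 nM, with an expected range of 3500 nM to 18000 nM.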

Compound 4, half-maximal inhibitory concentration: 11900 nM
The estimate for compound 4 lay 1.5-fold (0.17 log units) below the measured number; the measured number falls inside the stated range.
By their numbers in this assay, from the lowest: compounds 3, 1, 2 and 4 (each within the scatter of the next, the first and the last beyond it).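

In this assay, a 2.5-fold higher number from compound 3 to compound 4 (0.39 log units; beyond the scatter) shows that the group on the aromatic carbon para to a large group can move the number beyond the scatter, with methyl in place of tert-butyl. By contrast, a 1.2-fold higher number from compound 2 to compound 4 (0.08 log units; within the scatter) with hydrogen in place of methyl and a 1.3-fold higher number from compound 1 to compound 4 (0.10 log units; within the scatter) with 4-methylphenyl in place of 2-ethylphenyl both stay within it. Nothing available here explains the tert-butyl step.

As far as these compounds go, whether an isopropyl group or a longer chain at this carbon would read like tert-butyl or like methyl remains open. From the compounds shown here alone, an amine or a carboxylic acid there is equally open.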